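The source may hold more compounds than are shown below. What is called first, only, known or untested is meant among the compounds shown, and "the series" means these compounds.

Compound 1 `O=c1[nH]c(=O)n([C@H]2C[C@H](O)[C@@H](CO)O2)cc1CF`: > 1000 uM (a limit)
Compound 2 `CC(=O)OC[C@H]1O[C@@H](n2cc(C(F)F)c(=O)[nH]c2=O)C[C@@H]1OC(C)=O`: 14 uM
Compound 3 `CC(=O)OC[C@H]1O[C@@H](n2cc(C(F)(F)F)c(=O)[nH]c2=O)C[C@@H]1OC(C)=O`: 19 uM

These values come from a functional assay on HL-60 cells (Homo sapiens) for inhibition, with a stated time of 48 h; on this read-out lower numbers stand for stronger inhibition and higher numbers for weaker inhibition. The value of compound 1 is a limit of the assay and not a number. Among the measured compounds shown here, compound 3 lies within the scatter of compound 2, its only numeric neighbour. Compound 4 `CC(=O)OC[C@H]1O[C@@H](n2cc(CF)c(=O)[nH]c2=O)C[C@@H]1OC(C)=O` is the next to be read, and its change from compound 3 is fluoromethyl in place of trifluoromethyl on an aromatic carbon. For the measured compounds named here, one measured step bears on this, a fluorine swapped for a hydrogen on that same carbon: a 1.4-fold higher number from compound 2 to compound 3 (0.13 log units; within the scatter). That single small step suggests no shift beyond the scatter, though it is thin support. The expected change is a 1.2-fold lower number from compound 3 to compound 4 (0.07 log units; within the scatter). For compound 4 the estimated value is 16 uM, with an expected range of 5 uM to 50 uM.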

Compound 4, concentration for 50% inhibition: 976 uM
Compound 4: middle estimate off by 61-fold (1.79 log units), on the low side, outside the stated range (above it).
By their numbers in this assay, from the lowest: compounds 2 and 3 (each within the scatter of the next); then compound 4. At a limit, above all of these: compound 1.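

Among the compounds shown here, on this aromatic carbon the step between difluoromethyl and trifluoromethyl stayed within the scatter, so the earlier compounds gave no sign that the fluorine count matters. Fluoromethyl breaks that picture, with a 51-fold higher number from compound 3 to compound 4 (1.71 log units; beyond the scatter) and a 70-fold higher number from compound 2 to compound 4 (1.84 log units; beyond the scatter), so the sharp change comes only when the group carries a single fluorine. The number for compound 4 now stands close to the top of what this read-out reports: the limit of > 1000 uM in this assay, at which 1 of the 4 values shown sits.

As far as these compounds go, how a plain methyl, a hydroxymethyl or an amine on this carbon would read remains open.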